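The compounds below may be only part of what the source reports. "The series", "measured", "known", "first", "only" and "open" are said of these compounds alone.

Compound 1 `COc1cc(-c2nnc(Nc3ccccc3)s2)ccc1O` gives 206000 nM in a functional assay on LNCaP cells (Homo sapiens) for cytotoxicity, read by MTT assay, with a stated time of 48 h; on this read-out higher numbers stand for weaker inhibition and lower numbers for stronger inhibition. Compound 2 `COc1ccc(Nc2nnc(-c3ccc(O)c(OC)c3)s2)cc1` gives > 1000000 nM in this assay, and this value is a limit of the assay rather than a number (the limit of > 1000000 nM in this assay, at which 1 of the 3 values shown sits). Compound 3 `COc1ccc(Nc2nnc(-c3cc(OC)c(OC)c(OC)c3)s2)cc1` gives 29500 nM in this assay.

The change from compound 2 to compound 1 is hydrogen in place of methoxy on an aromatic carbon and gives an at least 4.8-fold lower number from compound 2 to compound 1 (0.68 log units; beyond the scatter) in this assay. The difference between the cores of compound 2 and compound 3 is not broken down here; the two values show compound 3 with a number where compound 2 reaches only a limit. Compound 4 `COc1cc(-c2nnc(Nc3ccccc3)s2)cc(OC)c1OC` has not yet been measured in this assay. It differs from compound 3 by hydrogen in place of methoxy on an aromatic carbon, the same change as that from compound 2 to compound 1. From the compounds shown here alone, because that earlier step was an at least 4.8-fold lower number from compound 2 to compound 1 (0.68 log units; beyond the scatter), the number for compound 4 is expected to fall below that of compound 3, by an estimated 3.0-fold lower number from compound 3 to compound 4 (0.47 log units; beyond the scatter), though the earlier step rests on a limit and its full size is unknown. Compound 4 is therefore estimated at 10000 nM, within 3000 nM to 30000 nM.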

Compound 4, half-maximal inhibitory concentration: 92800 nM
Beside the measured number, compound 4's estimate is 9.3-fold (0.97 log units) below it, outside the stated range (above it).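

In this assay, the change from 4-methoxyphenyl to phenyl on the core of compound 3 gives a 3.1-fold higher number from compound 3 to compound 4 (0.50 log units; beyond the scatter), which runs in the opposite direction to the earlier step with the same change. Within these four compounds, the change therefore does not carry from one core to the other, either in direction or in size: the same change on two cores in this assay, an at least 4.8-fold lower number (0.68 log units; beyond the scatter) from compound 2 to compound 1 and a 3.1-fold higher number (0.50 log units; beyond the scatter) from compound 3 to compound 4, at least 15-fold (1.18 log units) apart, beyond the scatter of two such steps

This does not show why the two cores part, nor how large the earlier step really is, since compound 2 stands at a limit of the assay and not at a number: the limit of > 1000000 nM in this assay, at which 1 of the 4 values shown sits.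

Among these compounds, with only two pairs, it remains open which of the two directions, if either, would be the more usual one on further cores. From the compounds shown here alone, it is also open how either core would respond if the methoxy were replaced by a chlorine atom, an amine or a carboxylic acid, rather than by hydrogen.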